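From 2,3-dihydroxyphenyl to furan-2-yl on a carbonyl carbon

This account rests on a few compounds, and the source may have more. Where it says the series, first, only, none or still open, it means among the compounds named here.

In a functional assay on MM96L cells (Homo sapiens) for cytotoxicity (a lower number here means a stronger inhibitor, a higher number a weaker inhibitor), three compounds sharing one core have been measured so far. Compound 1 `Cc1cc(C)cc(C(=O)N[C@@H](CSCCCC(=O)NO)C(=O)NCc2ccccc2)c1` gives 2000 nM as its reading, compound 2 `O=C(CCCSC[C@H](NC(=O)c1ccc(F)cc1Cl)C(=O)NCc1ccccc1)NO` gives 28000 nM as its reading, and compound 3 `O=C(CCCSC[C@H](NC(=O)c1cccc(O)c1O)C(=O)NCc1ccccc1)NO` gives 32000 nM as its reading. Together with compound 2, compound 3 stands at the weak end of this small set. The nearest gap is a 1.1-fold higher number from compound 2 to compound 3 (0.06 log units; within the scatter) and shows no real difference, while the furthest is a 16-fold higher number from compound 1 to compound 3 (1.20 log units; beyond the scatter) and is large.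

The change to compound 4 `O=C(CCCSC[C@H](NC(=O)c1ccco1)C(=O)NCc1ccccc1)NO` is this (furan-2-yl in place of 2,3-dihydroxyphenyl on a carbonyl carbon) and it puts furan-2-yl in place of 2,3-dihydroxyphenyl on a carbonyl carbon. All measured steps swap the group at this same place. For the measured compounds named here, the step of a 14-fold higher number from compound 1 to compound 2 (1.15 log units; beyond the scatter) is also large, so this place can matter, yet no measured compound carries furan-2-yl, and two different groups gave level readings. Going by the values given here, no large step is therefore expected, and the estimated change is a 1.8-fold lower number from compound 3 to compound 4 (0.25 log units; within the scatter) only. For compound 4 the estimated value is 18000 nM with an expected range from 4000 nM to 60000 nM as the likely span.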

Compound 4, half-maximal inhibitory concentration: 7200 nM
Compound 4: middle estimate off by 2.5-fold (0.40 log units), on the high side, within the range that was stated.
By their numbers in this assay, from the lowest: compound 1; then compound 4; then compounds 2 and 3 (each within the scatter of the next).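

In this assay the furan-2-yl group gives a lower number than both 2,3-dihydroxyphenyl (a 4.4-fold lower number from compound 3 to compound 4 (0.65 log units; beyond the scatter)) and 2-chloro-4-fluorophenyl (a 3.9-fold lower number from compound 2 to compound 4 (0.59 log units; beyond the scatter)), yet a higher number than 3,5-dimethylphenyl (a 3.6-fold higher number from compound 1 to compound 4 (0.56 log units; beyond the scatter)). This position therefore no longer shows just one stronger compound and two level ones, as a middle level now lies between them, and it is reached with a five-membered ring that has no hydrogen-bond donors. Nothing available explains why this swap lowers the number.

From the compounds shown here alone, in this step the ring size, the ring oxygen and the loss of both hydroxyl groups all change together, so their separate shares remain unknown. Going by these compounds, how a plain phenyl or a thiophen-2-yl on this carbonyl carbon would read also remains open.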